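A few compounds are considered here, and "the series" means these few. Any claim that something is new, unique, unknown or untested is made for them only; others in the source may bear on it.

Compound 1 `COc1cc(OC)c(/C=C/C(=O)/C=C/c2cc3ccccc3nc2Cl)c(OC)c1` and compound 2 `COc1ccc(/C=C/C(=O)/C=C/c2cc3ccccc3nc2Oc2ccccc2)c(OC)c1` have both been tested, while compound 3 `COc1cc(OC)c(/C=C/C(=O)/C=C/c2cc3ccccc3nc2Oc2ccccc2)c(OC)c1` has not. In a functional assay on PC-3 cells (Homo sapiens) for cytotoxicity, read by MTT assay, with a stated time of 48 h (on this read-out higher numbers stand for weaker inhibition and lower numbers for stronger inhibition), compound 1 gives > 10000 nM and this is a limit of the assay, not a number. In this assay compound 2 gives > 10000 nM and this too is only a limit. Compound 2 therefore has no number of its own, and the data so far amount to the limit of > 10000 nM in this assay, at which 2 of the 2 values shown sit, and nothing finer.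

The move to compound 3 puts methoxy in place of hydrogen on an aromatic carbon, ortho to a large group and meta to two methoxy groups: methoxy in place of hydrogen on an aromatic carbon is the whole of the difference. No measured step sizes this change in this assay so no step beyond the scatter is expected, in either direction. The methoxy pattern of compound 3 is shared by compound 1, which reads > 10000 nM as a limit, and this gives no sign of a gain. The step is estimated as a number no higher from compound 2 to compound 3 (the limit leaves the size open) and so stays small. Compound 3 is expected at 10000 nM within an estimated range of 3000 nM to 30000 nM if a number is reported at all.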

Compound 3, half-maximal inhibitory concentration: > 10000 nM
Compound 3 gave a limit, no number; the forecaster's own chance of this, stated with the estimate: 65%; the middle value sits exactly at the limit.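

No step can be read from compound 1 or compound 2 to compound 3 in this assay, and all three compounds stand at one limit of the assay, not at numbers: the limit of > 10000 nM in this assay, at which 3 of the 3 values shown sit. The compounds shown leave open whether methoxy in place of hydrogen, or phenoxy in place of chloro, changes the read-out at all.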